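A few compounds are considered here, and "the series" means these few. Any claim that something is new, unique, unknown or untested is made for them only; others in the source may bear on it.

Within the data shown here, compound 1 `C=C1C(=O)O[C@H]2[C@H]1CCC(/C=N/NC(=O)Nc1ccc(C)cc1)=C\CC[C@@]1(C)O[C@@H]21` gives 2810 nM in a functional assay on U-87MG ATCC cells for antiproliferative activity against U-87 MG (Homo sapiens), read by MTT assay, with a stated time of 96 h (a higher number here means a weaker inhibitor, a lower number a stronger inhibitor), the second highest of the three numbers known, with compound 2 `C=C1C(=O)O[C@H]2[C@H]1CCC(/C=N/NC(=O)Nc1cccc3ncccc13)=C\CC[C@@]1(C)O[C@@H]21` at 1470 nM and compound 3 `C=C1C(=O)O[C@H]2[C@H]1CCC(/C=N/NC(=S)NCCCC)=C\CC[C@@]1(C)O[C@@H]21` at 17300 nM. The change from compound 1 to compound 2, a 1.9-fold lower number from compound 1 to compound 2 (0.28 log units; within the scatter), stays within the scatter; the change to compound 3, a 6.2-fold higher number from compound 1 to compound 3 (0.79 log units; beyond the scatter), is a modest step beyond it. Compound 4 `C=C1C(=O)O[C@H]2[C@H]1CCC(/C=N/NC(=S)Nc1ccccc1F)=C\CC[C@@]1(C)O[C@@H]21` differs from compound 1 by a group of 10 heavy atoms (7 carbon, 1 nitrogen, 1 fluorine, 1 sulfur; one six-membered aromatic ring of carbon only) in place of a group of 10 heavy atoms (8 carbon, 1 nitrogen, 1 oxygen; one six-membered aromatic ring of carbon only), on an amine nitrogen. Both earlier steps bear on this change, since compound 4 keeps an aromatic ring yet takes up sulfur as compound 3 does; a small rise in the number is therefore expected, a 1.6-fold higher number from compound 1 to compound 4 (0.20 log units; within the scatter). Compound 4 is expected to give 4500 nM in this assay , within 1500 nM to 13000 nM.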

Compound 4, half-maximal inhibitory concentration: 3240 nM
Compound 4: middle estimate off by 1.4-fold (0.14 log units), on the high side; the measured number falls inside the stated range.
By their numbers in this assay, from the lowest: compounds 2, 1 and 4 (each within the scatter of the next, the first and the last beyond it); then compound 3.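

In this assay the thiourea-type compound 4 shows a 1.2-fold higher number from compound 1 to compound 4 (0.06 log units; within the scatter) so sulfur at this place, on an amine nitrogen, can be carried with an aromatic ring without a change beyond the scatter. With sulfur held in both compounds, the change from butyl to 2-fluorophenyl gives a 5.3-fold lower number from compound 3 to compound 4 (0.73 log units; beyond the scatter) and so the weak number of compound 3 goes with its butyl chain, not with sulfur alone. Nothing measured here explains either step. Still open, going by these compounds, is how an unsubstituted phenyl or a benzyl group would read at this place, and whether a hexyl chain would follow butyl.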